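Oxime ethers of an indole-bearing core: methyl to trifluoromethyl

A few compounds are considered here, and "the series" means these few. Any claim that something is new, unique, unknown or untested is made for them only; others in the source may bear on it.

Of the compounds shown here, two of a shared core have been measured in a functional assay on T-24 cells (Homo sapiens) for cytotoxicity, read by MTT assay, with a stated time of 2 days; on this read-out lower numbers stand for stronger inhibition and higher numbers for weaker inhibition. Compound 1 `O/N=C1/C(c2c[nH]c3ccc(OCc4ccccc4)cc23)=Nc2ccc(OCc3ccccc3)cc21` carries two benzyloxy groups and an unsubstituted oxime; in this assay compound 1 gives 11800 nM. Compound 2 `Cc1ccc(CO/N=C2/C(c3c[nH]c4ccc(Br)cc34)=Nc3ccc(Br)cc32)cc1` carries two bromine atoms and a 4-methylbenzyl oxime ether; in this assay compound 2 gives 21400 nM. The two numbers sit within the scatter of each other, so compound 2 cannot be set apart from compound 1 on what is shown.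

Compound 3 `FC(F)(F)c1ccc(CO/N=C2/C(c3c[nH]c4ccc(Br)cc34)=Nc3ccc(Br)cc32)cc1` differs from compound 2 in one place: trifluoromethyl in place of methyl on an aromatic carbon. Among the compounds with values here, no measured pair shows this change, so there is nothing to lean on. He therefore expects compound 3 to stay close to compound 2, with the step from compound 2 to compound 3 estimated as a 1.1-fold lower number from compound 2 to compound 3 (0.03 log units; within the scatter), none beyond the scatter. In this assay compound 3 is estimated at 20000 nM, within a range of 8000 nM to 50000 nM.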

Compound 3, half-maximal inhibitory concentration: 9880 nM
Beside the measured number, compound 3's estimate is 2.0-fold (0.31 log units) above it; measured number inside the range.
By their numbers in this assay, from the lowest: compounds 3, 1 and 2 (each within the scatter of the next, the first and the last beyond it).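

Compound 1 and compound 2 differ in more than one place, so only now does a single change stand alone: in this assay, trifluoromethyl in place of methyl on the benzyl group of the oxime ether gives a 2.2-fold lower number from compound 2 to compound 3 (0.34 log units; beyond the scatter), a modest step. It shows that this position, on an aromatic carbon para to a large group, responds to a change of substituent, and that trifluoromethyl is tolerated there with no loss on this read-out. Nothing measured here accounts for the step.

Only methyl and trifluoromethyl are shown at this carbon, so it remains open whether the step belongs to trifluoromethyl alone. A chlorine atom, a methoxy group, a nitrile or an amine at the same place could settle that.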